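The source may report more compounds than this note shows. Statements on the series, on what has been measured and on what is new or still open speak of the compounds shown alone.

Compound 1 `Clc1ccc(N2CC[C@H]3CN[C@H]3C2)cn1` gives 13 nM in a functional assay on HEK293 cells for agonist activity at Neuronal acetylcholine receptor; alpha4/beta2 (Homo sapiens), read by FLIPR (a lower number here means that less compound is needed, a higher number that more compound is needed for the effect), the second highest of the three numbers measured. Its mirror image, compound 2 `Clc1ccc(N2CC[C@@H]3CN[C@@H]3C2)cn1`, gives 24 nM, and the step of a 1.8-fold higher number from compound 1 to compound 2 (0.27 log units; within the scatter) rests only on the configuration as drawn (the fact that compounds 1 and 2 differ only in the configuration as drawn). Compound 3 `Clc1cc(N2CC[C@H]3CN[C@H]3C2)cnc1Cl` gives 12 nM, so the step of a 1.1-fold lower number from compound 1 to compound 3 (0.03 log units; within the scatter) is small. Compound 4 `O=[N+]([O-])c1ccc(N2CC[C@H]3CN[C@H]3C2)cn1` differs from compound 1 by nitro in place of chloro on an aromatic carbon, on the carbon next to the ring nitrogen. For the measured compounds named here, no measured step replaces one group by another on that carbon; the step from compound 1 to compound 3 only adds a chloro elsewhere and stays within the scatter. Compound 4 is therefore expected at 20 nM in this assay, between 6 nM and 65 nM, a step of a 1.5-fold higher number from compound 1 to compound 4 (0.19 log units; within the scatter) that need not exceed the scatter.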

Compound 4, half-maximal effective concentration: 100 nM
Estimate against measurement, compound 4: 5.0-fold (0.70 log units) below; measured number outside the range, above it.
By their numbers in this assay, from the lowest: compounds 3, 1 and 2 (each within the scatter of the next); then compound 4.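

In this assay, for the compounds shown here, nitro in place of chloro next to the ring nitrogen gives a 7.7-fold higher number from compound 1 to compound 4 (0.89 log units; beyond the scatter), the only step here beyond the scatter. This position therefore responds to the exchange of its group, which neither the added chloro of compound 3 nor the mirror image, compound 2, had shown. Nothing given here accounts for the size of this step.

Only chloro and nitro are shown on this carbon, so how a nitrile, a methoxy group or an amine would read there stays open. Also open, from the compounds shown here alone, is whether the same exchange gives a similar step on the core of compound 2 or alongside the second chloro of compound 3.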